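From compound 2 to compound 4

This account rests on a few compounds, and the source may have more. Where it says the series, first, only, none or still open, it means among the compounds named here.

Values in a functional assay on G-361 cells (Homo sapiens) for antiproliferative activity; on this read-out higher numbers stand for weaker inhibition and lower numbers for stronger inhibition:
compound 1 `Nc1n[nH]c(N)c1/N=N/c1ccccc1[N+](=O)[O-]`: > 100000 nM
compound 2 `Nc1n[nH]c(N)c1/N=N/c1ccccc1O`: > 100000 nM
compound 3 `Nc1n[nH]c(N)c1/N=N/c1cccc(O)c1`: > 100000 nM

Within the data shown here, the series has no readable number so far: the limit of > 100000 nM in this assay, at which 3 of the 3 values shown sit. Compound 2 gives > 100000 nM, and this is a limit of the assay, not a number. The next structure is compound 4 `Nc1n[nH]c(N)c1/N=N/c1ccccc1CO`, and the change is hydroxymethyl in place of hydroxy on an aromatic carbon.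

Among the measured compounds shown here, the one measured step that bears on this change is a step that the two limits leave unreadable from compound 1 to compound 2. It concerns the same aromatic substituent of compound 2, but it gives no size to carry over. With no readable step available, no step beyond the scatter is expected in this assay, in either direction, and a further limit is the likeliest report. The estimated step is a number no higher from compound 2 to compound 4 (the limit leaves the size open). For compound 4 the expected value is 100000 nM, with an estimated range from 40000 nM to 200000 nM.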

Compound 4, half-maximal inhibitory concentration: > 100000 nM
Compound 4 was reported as a limit; the forecaster's own chance of this, stated with the estimate: 80%; the middle value sits exactly at the limit.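

Compound 4 gives > 100000 nM, which is a limit of the assay and not a number. Among these compounds, no step from compound 1 or compound 2 to compound 4 can be read. The compounds shown leave open which aromatic substituent, if any, would give a readable value in this assay, and the series still sits at one value: the limit of > 100000 nM in this assay, at which 4 of the 4 values shown sit.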